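This account rests on a few compounds, and the source may have more. Where it says the series, first, only, none or still open, it means among the compounds named here.

compound 1 `CC(C)CCC1C(=O)Nc2ccc(Nc3ccc(Cl)cc3)cc21` gives 2000 nM
compound 2 `O=C1Nc2ccc(Nc3ccc(Cl)cc3)cc2C1CC1CCCCC1` gives 16600 nM
compound 3 `CCCCCC1(O)C(=O)Nc2ccc(Nc3ccc(OC)cc3)cc21` gives 8000 nM

In a functional assay on A549 cells (Homo sapiens) for antiproliferative activity, read by MTT assay, with a stated time of 48 h (a lower number here means a stronger inhibitor, a higher number a weaker inhibitor), compound 3 takes the middle place of the three: its 8000 nM lies between compound 1 at 2000 nM and compound 2 at 16600 nM, and the gap to each is beyond the scatter.

Compound 4 `CCCCCCC1(O)C(=O)Nc2ccc(Nc3ccc(OC)cc3)cc21` differs from compound 3 in one place: methyl in place of hydrogen on a saturated chain carbon, five bonds along the chain from a saturated ring carbon. This is methyl in place of hydrogen on a saturated chain carbon, five bonds along the chain from a saturated ring carbon, and the rest of the molecule stays the same.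

Within the data shown here, only one measured step offers any guide: an 8.3-fold higher number from compound 1 to compound 2 (0.92 log units; beyond the scatter), with cyclohexyl in place of isobutyl on a saturated chain carbon bound to a saturated ring carbon. That step is modest, though beyond the scatter. It is a larger change than the one here, and it was measured on compounds that differ from compound 3 elsewhere too. Among the measured compounds shown here, no measured pair shows what adding methyl at the end of such a chain does, so the direction stays open. A step smaller than an 8.3-fold higher number from compound 1 to compound 2 (0.92 log units; beyond the scatter) is therefore expected, probably none beyond the scatter in this assay.

The expected step is a 1.1-fold lower number from compound 3 to compound 4 (0.06 log units; within the scatter). For compound 4 the estimated value is 7000 nM, with an expected range from 2500 nM to 20000 nM.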

Compound 4, half-maximal inhibitory concentration: 18600 nM
The estimate for compound 4 lay 2.7-fold (0.42 log units) below the measured number, and the stated range covers the measured number.
By their numbers in this assay, from the lowest: compound 1; then compound 3; then compounds 2 and 4 (each within the scatter of the next).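

In this assay, methyl in place of hydrogen on a saturated chain carbon, five bonds along the chain from a saturated ring carbon, gives a 2.3-fold higher number from compound 3 to compound 4 (0.37 log units; beyond the scatter). So even one added carbon this far out along the chain moves the number beyond the scatter, towards a weaker inhibitor, and the direction of this change, open until now, is settled for this pair. Among these compounds, the only earlier step, an 8.3-fold higher number from compound 1 to compound 2 (0.92 log units; beyond the scatter), also raised the number, but it swapped isobutyl for cyclohexyl on other compounds, so the two steps together make no rule, and nothing available explains the rise at the chain end.

The compounds shown leave open whether a longer chain, such as heptyl or octyl, would raise the number further, and whether a shorter chain, such as butyl, would lower it, or an amine or a carboxylic acid at the chain end would change the picture. They also leave open whether methyl in place of hydrogen at the end of the chain would have a similar effect on the core of compound 1.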